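A few compounds are considered here, and "the series" means these few. Any claim that something is new, unique, unknown or untested is made for them only; others in the source may bear on it.

In a functional assay on NCI-H1581 cells (Homo sapiens) for antiproliferative activity, read by CCK-8 assay, with a stated time of 72 h; on this read-out lower numbers stand for stronger inhibition and higher numbers for weaker inhibition:
Compound 1 `CCN1CCN(c2ccc(C(=O)Nc3n[nH]c4nc(-c5c(Cl)c(OC)cc(OC)c5Cl)ccc34)cc2)CC1`: 0.7 nM
Compound 2 `COc1cc(OC)c(Cl)c(-c2ccc3c(NC(=O)c4ccc(N5CCN(S(C)(=O)=O)CC5)cc4)n[nH]c3n2)c1Cl`: 245 nM

Compound 2 holds the higher of the two numbers, so it is the weaker of the pair. Compound 3 `COc1cc(OC)c(Cl)c(-c2ccc3c(NC(=O)c4ccc(N(C)C)cc4)n[nH]c3n2)c1Cl` departs from it through dimethylamino in place of 4-(methylsulfonyl)piperazin-1-yl on an aromatic carbon. Among the compounds with values here, only one measured step bears on this, a 350-fold higher number from compound 1 to compound 2 (2.54 log units; beyond the scatter), which came with methylsulfonyl in place of ethyl on an amine nitrogen in a ring. Compound 3 also lacks the methylsulfonyl, but it lacks the ring too, and no measurement tests dimethylamino directly. A moderate step towards a lower number in this assay is therefore expected, smaller than the measured one. The expected change is a 4.9-fold lower number from compound 2 to compound 3 (0.69 log units; beyond the scatter). For compound 3 the estimated value is 50 nM, with an expected range from 8 nM to 300 nM.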

Compound 3, half-maximal inhibitory concentration: 294 nM
Compound 3: middle estimate off by 5.9-fold (0.77 log units), on the low side; the range from low to high includes it.
By their numbers in this assay, from the lowest: compound 1; then compounds 2 and 3 (each within the scatter of the next).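

In this assay, dimethylamino in place of 4-(methylsulfonyl)piperazin-1-yl gives a 1.2-fold higher number from compound 2 to compound 3 (0.08 log units; within the scatter), so on this aromatic carbon, going from 10 heavy atoms and a ring to 3 heavy atoms and no ring leaves the read-out within the scatter. Dimethylamino in place of 4-ethylpiperazin-1-yl gives a 420-fold higher number from compound 1 to compound 3 (2.62 log units; beyond the scatter), so among these three compounds the low number is found only with the ethyl-bearing ring, not with the ring as such or with any amine at this place. Nothing available here accounts for why that one group stands apart.

The compounds shown leave open whether a 4-methylpiperazin-1-yl, or a piperazin-1-yl with only hydrogen on the outer nitrogen, would keep the low number. Also open, on these data alone, is whether a morpholin-4-yl or an open chain such as 2-(dimethylamino)ethoxy would do so.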